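A few compounds are considered here, and "the series" means these few. Any claim that something is new, unique, unknown or untested is made for them only; others in the source may bear on it.

Compound 1 `Cc1ccc(Nc2nccc(Nc3ccc4nc[nH]c4c3)n2)cc1`: > 25000 nM
Compound 2 `CS(=O)(=O)Nc1cccc(Nc2nccc(Nc3ccc4nc[nH]c4c3)n2)c1`: > 25000 nM
Compound 3 `NS(=O)(=O)c1cccc(Nc2nccc(Nc3ccc4nc[nH]c4c3)n2)c1`: > 25000 nM

In an ADME assay on HepG2 cells (Homo sapiens) for inhibition, read by fluorescence and resazurin assay, with a stated time of 72 h (a higher number here means a weaker inhibitor, a lower number a stronger inhibitor), compound 1 gives > 25000 nM, which is a limit of the assay and not a number. Compound 2 also gives only a limit, > 25000 nM. Compound 3 too gives only a limit, > 25000 nM. Compound 1 therefore has no exact standing among the three.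

Compound 4 `NS(=O)(=O)c1ccc(Nc2nccc(Nc3ccc4nc[nH]c4c3)n2)cc1` is compound 1 with sulfamoyl in place of methyl on an aromatic carbon, para to a large group: sulfamoyl in place of methyl on an aromatic carbon. Among the measured compounds shown here, the only measured step that brings in a sulfamoyl group is a step that the two limits leave unreadable from compound 2 to compound 3, so it offers no size to carry over. The expectation rests on a simpler observation. For the measured compounds named here, because the limit of > 25000 nM in this assay, at which 3 of the 3 values shown sit, describes every compound measured so far, no step beyond the scatter is expected in this assay, in either direction, and another limit is the likeliest result. For compound 4 the estimated value is 25000 nM, with an expected range from 12000 nM to 50000 nM. This estimate means an expected a number no higher from compound 1 to compound 4 (the limit leaves the size open).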

Compound 4, half-maximal inhibitory concentration: > 25000 nM
Compound 4: only a limit was reported (the forecaster's own chance of this, stated with the estimate: 85%); the middle value sits exactly at the limit.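

Among the compounds shown here, compound 1 and compound 4 both give only a limit of the assay and not a number, so no step between them can be read in this assay. The compounds shown leave open whether any change on the shared core alters the result, as they all share one reading: the limit of > 25000 nM in this assay, at which 4 of the 4 values shown sit.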